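Methoxy for methyl on the unvaried aryl ring

The compounds below may be only part of what the source reports. "The series", "measured", "known", "first", "only" and "open" are said of these compounds alone.

Compound 1 `Cc1ccc(-c2nnc(NC(=O)/C=C/c3ccc(C(F)(F)F)cc3)s2)cc1` gives 1.1 ug/mL in a functional assay on MCF7 cells (Homo sapiens) for antiproliferative activity, read by MTT assay, with a stated time of 48 h (a lower number here means a stronger inhibitor, a higher number a weaker inhibitor), the second highest of three numbers: compound 3 `Cc1ccc(-c2nnc(NC(=O)/C=C/c3ccc(F)cc3)s2)cc1` gives 1.27 ug/mL, and compound 2 `Cc1ccc(/C=C/C(=O)Nc2nnc(-c3ccc(C)cc3)s2)cc1` gives 0.61 ug/mL. Compound 4 `COc1ccc(-c2nnc(NC(=O)/C=C/c3ccc(C(F)(F)F)cc3)s2)cc1` differs from compound 1 by methoxy in place of methyl on an aromatic carbon. The measured steps all alter the group on the ring bearing trifluoromethyl, fluoro or methyl: a 1.8-fold lower number from compound 1 to compound 2 (0.26 log units; within the scatter), a 1.2-fold higher number from compound 1 to compound 3 (0.06 log units; within the scatter) and a 2.1-fold higher number from compound 2 to compound 3 (0.32 log units; beyond the scatter). Within the data shown here, none alters the ring that carries the methyl of compound 1, so no step bears directly on this change, and the steps that exist are small. Compound 4 is therefore expected to show no change at the digits printed from compound 1 to compound 4 (within the scatter), a step inside the scatter. The estimate for compound 4 is 1.1 ug/mL, with a range from 0.5 ug/mL to 2.5 ug/mL.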

Compound 4, half-maximal inhibitory concentration: 0.79 ug/mL
The estimate for compound 4 lay 1.4-fold (0.14 log units) above the measured number; measured number inside the range.
By their numbers in this assay, from the lowest: compounds 2, 4, 1 and 3 (each within the scatter of the next, the first and the last beyond it).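

Going from 4-methylphenyl to 4-methoxyphenyl gives a 1.4-fold lower number from compound 1 to compound 4 (0.14 log units; within the scatter) in this assay and is the only reading on this ring among the compounds shown. This position, para to a large group, thus takes methoxy in place of methyl without a step beyond the scatter. No evidence on hand bears on this result.

From the compounds shown here alone, whether an amine, a carboxylic acid or a longer chain here would also stay within the scatter of compound 1 remains open. Also open, going by these compounds, is whether methoxy would give the same outcome alongside the methyl of compound 2 or the fluoro of compound 3.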